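The compounds below may be only part of what the source reports. "The series", "measured", "known", "first", "only" and "open" are said of these compounds alone.

In an ADME assay on THP-1 cells (Homo sapiens) for cytotoxicity, read by MTT assay, with a stated time of 72 h (a lower number here means a stronger inhibitor, a higher number a weaker inhibitor), compound 2 (`COc1cccc(/C=C/C(=O)c2c(O)c3ccccc3[nH]c2=O)c1`) gives 38500 nM and compound 1 (`COc1cc(/C=C/C(=O)c2c(O)c3ccccc3[nH]c2=O)ccc1O`) gives 23300 nM as its reading, so these two values lie within the scatter of each other (a 1.7-fold higher number from compound 1 to compound 2 (0.22 log units; within the scatter)). Compound 3 (`Cc1ccccc1/C=C/C(=O)c1c(O)c2ccccc2[nH]c1=O`) gives > 50000 nM as its reading, which is a limit of the assay and not a number. Compound 4 (`COc1ccc(/C=C/C(=O)c2c(O)c3ccccc3[nH]c2=O)cc1OC`) differs from compound 2 by one change (methoxy in place of hydrogen on an aromatic carbon): methoxy in place of hydrogen on an aromatic carbon, para to a large group. The other measured change, 2-methylphenyl in place of 3-methoxyphenyl, is also not shown beyond the scatter (an at least 1.2-fold higher number from compound 2 to compound 3 (0.11 log units; that floor lies within the scatter)). No clear shift is therefore expected in this assay here. The estimated step is small (a 1.2-fold lower number from compound 2 to compound 4 (0.08 log units; within the scatter)) and stays within the scatter. Compound 4 is expected at 32000 nM with an estimated range from 17000 nM to 50000 nM in this test.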

Compound 4, half-maximal inhibitory concentration: > 50000 nM
Compound 4 was reported as a limit; the forecaster's own chance of this, stated with the estimate: 20%; at least 1.5-fold (0.19 log units) between middle value and limit.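

In this assay compound 4 reads as a limit of the assay and not a number. Even so, putting methyl in place of the hydrogen on the hydroxy oxygen of compound 1 gives a step that clears the scatter (an at least 2.1-fold higher number from compound 1 to compound 4 (0.33 log units; beyond the scatter)), so a free hydroxy at this place may matter more than extra bulk. Adding the methoxy to compound 2 shows much less, only a floor that stays within the scatter (an at least 1.2-fold higher number from compound 2 to compound 4 (0.11 log units; that floor lies within the scatter)).

Going by these compounds, how far compound 4 really lies past the measurable range stays unknown: the limit of > 50000 nM in this assay, at which 2 of the 4 values shown sit. On these data alone, whether an amine or a carboxylic acid at this place would bring a measurable reading also stays open.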